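The compounds below may be only part of what the source reports. "The series", "measured", "known", "first", "only" and "open" are said of these compounds alone.

Compound 2 `COc1cc(/C=N/N(C(=O)c2ccccc2)C(=O)c2ccncc2)ccc1O` sits at the upper end of the three numbers in an ADME assay on MT4 cells (Homo sapiens) for cytotoxicity (on this read-out lower numbers stand for higher toxicity in this test and higher numbers for lower toxicity in this test), giving 105 ug/mL; compound 3 `CSc1ccc(/C=N/N(C(=O)c2ccccc2)C(=O)c2ccncc2)cc1` gives 69 ug/mL and compound 1 `Cc1ccc(/C=N/N(C(=O)c2ccccc2)C(=O)c2ccncc2)cc1` gives 42 ug/mL. Only a 2.5-fold higher number from compound 1 to compound 2 (0.40 log units; beyond the scatter) is beyond the scatter, whereas a 1.5-fold lower number from compound 2 to compound 3 (0.18 log units; within the scatter) and a 1.6-fold higher number from compound 1 to compound 3 (0.22 log units; within the scatter) are not. Compound 4 `CCOc1cc(/C=N/N(C(=O)c2ccccc2)C(=O)c2ccncc2)ccc1O` differs from compound 2 by methyl in place of hydrogen on a saturated chain carbon bound to an oxygen on an aromatic ring, so the methoxy becomes an ethoxy. Among the compounds with values here, no measured step touches this chain. Within the data shown here, the nearest comparable small swap, a 1.6-fold higher number from compound 1 to compound 3 (0.22 log units; within the scatter), stayed within the scatter, and the one step beyond it, a 2.5-fold higher number from compound 1 to compound 2 (0.40 log units; beyond the scatter), exchanged a whole substituted phenyl. Compound 4 is therefore expected to show a step of a 1.1-fold lower number from compound 2 to compound 4 (0.02 log units; within the scatter), nothing beyond the scatter. Compound 4 is estimated at 100 ug/mL in this assay, between 55 ug/mL and 190 ug/mL.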

Compound 4, half-maximal cytotoxic concentration: >= 92 ug/mL
Compound 4 was reported as a limit (the forecaster's own chance of this, stated with the estimate: 5%); the middle value is on the limit's open side.
By their numbers in this assay, from the lowest: compounds 1, 3 and 2 (each within the scatter of the next, the first and the last beyond it).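

Compound 4 is reported in this assay only as a limit, >= 92 ug/mL, and the step from compound 2 to compound 4 cannot be read from it. The compounds shown leave open whether ethoxy in place of methoxy shifts this read-out at all.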